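The source may hold more compounds than are shown below. What is called first, only, known or untested is meant among the compounds shown, and "the series" means these compounds.

Measured so far in an ADME assay on WI-38 cells (Homo sapiens) for cytotoxicity, read by MTT assay, with a stated time of 72 h; on this read-out lower numbers stand for stronger inhibition and higher numbers for weaker inhibition:
- Compound 1 `O=C(O)CCc1cccc2c1B(O)OC2`: compound 1 gives > 100000 nM, a limit of the assay.
- Compound 2 `CCNC(=O)CCc1cccc2c1B(O)OC2`: compound 2 gives > 100000 nM, also a limit of the assay.
- Compound 3 `O=C(CCc1cccc2c1B(O)OC2)Nc1ccccc1`: compound 3 gives 30000 nM.

Among the measured compounds shown here, compound 3 thus holds the only plain number among the three, the other two being limits (the limit of > 100000 nM in this assay, at which 2 of the 3 values shown sit). Compound 4 `O=C(CCc1cccc2c1B(O)OC2)Nc1ccc(Br)cc1` differs from compound 3 by bromo in place of hydrogen on an aromatic carbon. For the measured compounds named here, no measured step changes a group on the anilino ring itself; the nearest are an at least 3.3-fold lower number from compound 2 to compound 3 (0.52 log units; beyond the scatter) and an at least 3.3-fold lower number from compound 1 to compound 3 (0.52 log units; beyond the scatter), both of which introduced the whole anilino group rather than decorating it. They give no guide to a bromo on that ring, so the step is expected to be a 1.2-fold lower number from compound 3 to compound 4 (0.08 log units; within the scatter), within the scatter. Compound 4 is therefore estimated at 25000 nM, between 8000 nM and 80000 nM.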

Compound 4, half-maximal inhibitory concentration: 42000 nM
The estimate for compound 4 lay 1.7-fold (0.23 log units) below the measured number; the range from low to high includes it.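

In this assay, among the compounds shown here, the first change on the anilino ring itself, bromo in place of hydrogen para to a large group, gives a 1.4-fold higher number from compound 3 to compound 4 (0.15 log units; within the scatter), so this single bromo does not separate the two compounds. The aromatic amide compound 4 still differs from the ethyl amide, with an at least 2.3-fold lower number from compound 2 to compound 4 (0.37 log units; beyond the scatter). Compound 2 gives only a limit, so that step has no exact size: the limit of > 100000 nM in this assay, at which 2 of the 4 values shown sit.

Going by these compounds, whether an amine, a methoxy group or a nitrile on this ring would move the number beyond the scatter remains open. So does the effect of a longer chain linking the amide to the core.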